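The compounds below may be only part of what the source reports. "The series", "measured", "known", "first", "only" and "open" are said of these compounds alone.

In a functional assay on HeLa cells (Homo sapiens) for inhibition, with a stated time of 72 h (a higher number here means a weaker inhibitor, a lower number a stronger inhibitor), compound 1 (`CC[C@@H](C)[C@H](NC(=O)OCc1ccccc1)C(=O)N(Cc1ccccc1)C1(C(=O)NCc2ccccc2)CCN(C(=O)OC(C)(C)C)CC1`) gives 11000 nM and compound 2 (`COC(=O)C[C@H](NC(=O)OCc1ccccc1)C(=O)N(C1CC1)C1(C(=O)NCc2ccccc2)CCN(Cc2ccccc2)CC1`) gives 4700 nM as measured values. Compound 3 (`CC(C)(C)OC(=O)N[C@@H](CC(=O)O)C(=O)N(Cc1ccccc1)C1(C(=O)NCc2ccccc2)CCN(Cc2ccccc2)CC1`) stands at > 200000 nM as a limit of the assay and not as a number. Compound 4 (`CN(C)C(=O)C[C@H](NC(=O)OC(C)(C)C)C(=O)N(Cc1ccccc1)C1(C(=O)NCc2ccccc2)CCN(Cc2ccccc2)CC1`) differs from compound 3 in one place (dimethylamino in place of hydroxy on a carbonyl carbon) with dimethylamino in place of hydroxy on a carbonyl carbon, so carboxy gives way to dimethylcarbamoyl. Among the measured compounds shown here, no pair of measured compounds shows this change directly. Of the three measured compounds, compound 3 alone carries carboxy, while compound 1 at 11000 nM and compound 2 at 4700 nM do not. The step of an at least 13-fold lower number from compound 3 to compound 4 (1.12 log units; beyond the scatter) is therefore expected to be large and toward stronger inhibition in this assay rather than within the scatter. For compound 4 the estimate is 15000 nM with an expected range of 4000 nM to 70000 nM in this reading.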

Compound 4, half-maximal inhibitory concentration: 68000 nM
Estimate against measurement, compound 4: 4.5-fold (0.66 log units) below, within the range that was stated.
By their numbers in this assay, from the lowest: compound 2; then compound 1; then compound 4. At a limit, above all of these: compound 3.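

In this assay, dimethylamino in place of hydroxy on a carbonyl carbon gives an at least 2.9-fold lower number from compound 3 to compound 4 (0.46 log units; beyond the scatter). The change thus turns a compound with only a limit into one with a measured value, so carboxy and dimethylcarbamoyl can be told apart at this position. The true size of the step stays unknown because compound 3 stands at a limit of the assay: the limit of > 200000 nM in this assay, at which 1 of the 4 values shown sits.

The compounds shown leave open how methylamino or a plain amino group on the same carbonyl carbon would read. They also leave open whether a longer chain in place of the carboxymethyl would change the value.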